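The compounds below may be only part of what the source reports. "The series", "measured", "known", "first", "only" and "open" are said of these compounds alone.

Compound 1 `O=C(OC1CCC(CN2CCN(c3cc(=O)c4cc(C(F)(F)F)cc([N+](=O)[O-])c4s3)CC2)CC1)c1cccc(C(F)(F)F)c1`: > 64 ug/mL
Compound 2 `O=C(OC1CCC(CN2CCN(c3cc(=O)c4cc(C(F)(F)F)cc([N+](=O)[O-])c4s3)CC2)CC1)C1CCCCC1`: > 64 ug/mL

In an ADME assay on Vero cells (Chlorocebus sabaeus) for cytotoxicity, read by MTT assay, with a stated time of 48 h (on this read-out higher numbers stand for weaker inhibition and lower numbers for stronger inhibition), compound 2 gives > 64 ug/mL, a limit of the assay and not a number. Compound 1 gives > 64 ug/mL, also a limit. Compound 2 therefore has no measured number, and the record holds only (the limit of > 64 ug/mL in this assay, at which 2 of the 2 values shown sit).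

Compound 3 `O=C(OC1CCC(CN2CCN(c3cc(=O)c4cc(C(F)(F)F)cc([N+](=O)[O-])c4s3)CC2)CC1)c1ccc(F)cc1` carries 4-fluorophenyl in place of cyclohexyl on a carbonyl carbon. Among the measured compounds shown here, the one measured step that bears on this change is a step that the two limits leave unreadable from compound 1 to compound 2, which swaps cyclohexyl for 3-(trifluoromethyl)phenyl at the same place. Its size cannot be read, so it offers no measured effect to carry over. Neither group on that carbonyl carbon moved its compound off the limit, so no step beyond the scatter is expected in this assay, and no direction can be given. The expected result is a step that the limit leaves unreadable from compound 2 to compound 3. For compound 3 the estimated value is 80 ug/mL, with an expected range from 40 ug/mL to 160 ug/mL, most likely reported as a limit again.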

Compound 3, half-maximal inhibitory concentration: > 64 ug/mL
Compound 3 was reported as a limit; the forecaster's own chance of this, stated with the estimate: 85%; the middle value is on the limit's open side.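

Among the compounds shown here, no step among compound 1, compound 2 and compound 3 can be read in this assay, since each result is a limit and not a number: the limit of > 64 ug/mL in this assay, at which 3 of the 3 values shown sit. The compounds shown leave open whether any group on that carbonyl carbon would give a readable value in this assay.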